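Plasma stability across ester and amide variants of one core

A few compounds are considered here, and "the series" means these few. Any claim that something is new, unique, unknown or untested is made for them only; others in the source may bear on it.

Compound 1, `CCCCCCCCOC(=O)c1c(C(C)(C)O)nc(CCC)n1Cc1ccc(-c2ccccc2C2=NNNN2)cc1`, gives 90.2% in an ADME assay on a cell-free system (plasma, Rattus norvegicus, strain Sprague-Dawley) for metabolic stability, with a stated time of 30 min, tested at 50 mg/mL; a higher number here means that more of the compound is left, a lower number that less of the compound is left. Among the three measured compounds it holds the second highest number: compound 3, `CCCc1nc(C(C)(C)O)c(C(=O)NCCCCCCC(=O)O)n1Cc1ccc(-c2ccccc2C2=NNNN2)cc1`, gives 97.5%, and compound 2, `CCCc1nc(C(C)(C)O)c(C(=O)OCCCCCCC(=O)OCC)n1Cc1ccc(-c2ccccc2C2=NNNN2)cc1`, gives 81.1%. Both neighbours lie within the scatter of compound 1, as a number 7.3 percentage points higher from compound 1 to compound 3 (within the scatter) and a number 9.1 percentage points lower from compound 1 to compound 2 (within the scatter) show. Going by the values given here, the only step beyond the scatter is a number 16.4 percentage points higher from compound 2 to compound 3 (beyond the scatter).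

Compound 4, `CCCc1nc(C(C)(C)O)c(C(=O)OCc2c[nH]c(=O)[nH]c2=O)n1Cc1ccc(-c2ccccc2C2=NNNN2)cc1`, has not yet been measured. It differs from compound 1 by a group of 8 heavy atoms (4 carbon, 2 nitrogen, 2 oxygen; one six-membered aromatic ring with 2 hetero atoms) in place of a group of 7 heavy atoms (7 carbon; no ring), on a saturated chain carbon bound to an oxygen next to a carbonyl group. As in the step from compound 1 to compound 2, the change sits on the chain attached to the oxygen next to the carbonyl group, while the carbonyl and the rest of the core stay as in compound 1. That step, a number 9.1 percentage points lower from compound 1 to compound 2 (within the scatter), is the one that bears most directly on the present change, and it stayed within the scatter. Among the compounds with values here, the step from compound 1 to compound 3 also stayed within the scatter, so no measured step from compound 1 gives grounds to expect a large move.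

For compound 4 in this assay a value of 82% is expected, with a range from 62% to 96%; the estimated step of a number 8.2 percentage points lower from compound 1 to compound 4 (within the scatter) would stay within the scatter, though a drop into the region of compound 2 cannot be ruled out.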

Compound 4, percent of the compound remaining: 96.3%
Estimate against measurement, compound 4: 14.3 percentage points below; measured number above the stated range.
By their numbers in this assay, from the lowest: compounds 2, 1, 4 and 3 (each within the scatter of the next, the first and the last beyond it).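

On the saturated chain carbon bound to an oxygen next to a carbonyl group, heptyl can give way to a group carrying a six-membered aromatic ring with 2 hetero atoms, and the number in this assay does not move beyond the scatter (a number 6.1 percentage points higher from compound 1 to compound 4 (within the scatter)). The ring-bearing ester also cannot be told apart from the amide with its carboxylic acid-ended chain (a number 1.2 percentage points lower from compound 3 to compound 4 (within the scatter)), so in this set a high number is not confined to the amide, though compound 2 goes against any general reading for the esters. The same position does separate the ring-bearing group from the chain ending in ethoxycarbonyl, in a modest step beyond the scatter (a number 15.2 percentage points higher from compound 2 to compound 4 (beyond the scatter)), which shows that the ester compounds here do not all share one level of stability.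

No measurement at hand accounts for these numbers. Still open, from the compounds shown here alone, is how this position would respond to a plain phenyl ring, a benzyl amine, a free carboxylic acid on the ester chain or a longer chain ending in ethoxycarbonyl.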